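The source may hold more compounds than are shown below. What is called first, only, known or untested is meant among the compounds shown, and "the series" means these compounds.

Working notes on the series, read in an ADME assay on Vero cells (Chlorocebus sabaeus) for cytotoxicity, read by MTT assay, with a stated time of 72 h; a higher number here means that more compound is tolerated, a lower number that less compound is tolerated. Of the compounds shown here, two carry numbers so far: compound 1 (`CC1(C)C=Cc2c(ccc(C(=O)/C=C/c3ccc(Cl)cc3)c2O)O1`) gives 92200 nM and compound 2 (`CC1(C)C=Cc2c(ccc(C(=O)/C=C/c3ccc(F)c(F)c3)c2O)O1`) gives 146000 nM. Going by the values given here, compound 2 stands level with compound 1, its only measured neighbour, and the two values lie within the scatter of each other.

The next compound, compound 3 (`CC1(C)C=Cc2c(ccc(C(=O)/C=C/c3ccccn3)c2O)O1`), carries pyridin-2-yl in place of 3,4-difluorophenyl on a double-bonded chain carbon bound to a double-bonded chain carbon.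

Among the compounds with values here, one measured step bears on this, at the same place, with 3,4-difluorophenyl in place of 4-chlorophenyl: a 1.6-fold higher number from compound 1 to compound 2 (0.20 log units; within the scatter). That step exchanged one carbon-only ring for another. Within the data shown here, no measured compound has a ring with a hetero atom at this place, so the guide is thin and the range must stay wide. No change beyond the scatter is expected in this assay, and no direction can be argued. The expected move is a 1.2-fold lower number from compound 2 to compound 3 (0.07 log units; within the scatter). For compound 3 the estimated value is 125000 nM, with an expected range of 50000 nM to 300000 nM.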

Compound 3, half-maximal cytotoxic concentration: 20500 nM
Compound 3: the middle estimate sits 6.1-fold (0.79 log units) above what was measured, and the stated range ends above it.
By their numbers in this assay, from the lowest: compound 3; then compounds 1 and 2 (each within the scatter of the next).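

In (this assay) this position proves sensitive to the ring it carries: pyridin-2-yl in place of 3,4-difluorophenyl gives a clear drop (a 7.1-fold lower number from compound 2 to compound 3 (0.85 log units; beyond the scatter)), and pyridin-2-yl in place of 4-chlorophenyl gives a drop of the same direction (a 4.5-fold lower number from compound 1 to compound 3 (0.65 log units; beyond the scatter)). Going by these compounds alone, the only earlier exchange at this place, between two carbon-only rings, stayed within the scatter (a 1.6-fold higher number from compound 1 to compound 2 (0.20 log units; within the scatter)), so pyridin-2-yl, the one six-membered aromatic ring here with a hetero atom, is the first group to show that less compound is tolerated with a change at this place. Nothing at hand gives a reason for this drop.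

Compound 3 both loses the halogen carried by compound 1 and compound 2 and gains a ring nitrogen, so these compounds cannot separate the two changes, and an unsubstituted phenyl would be needed to tell them apart. From the compounds shown here alone, it also remains open whether pyridin-3-yl or pyridin-4-yl would stand with compound 3 or with the two halogenated compounds.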